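The compounds below may be only part of what the source reports. "The series", "measured", "known", "first", "only" and "open" are said of these compounds alone.

Working notes on the series. The shared core carries an amide whose nitrogen bears a variable chain. Compound 1 `CCNC(=O)CCCSC[C@H](NC(=O)OCc1ccccc1)C(=O)Nc1ccccc1` bears ethyl there and gives 15% in an assay for inhibition of NAD-dependent protein deacylase sirtuin-6 (Homo sapiens), read by HPLC, with stated times of 15 min and 1 h, tested at 333 uM; on this read-out higher numbers stand for more inhibition at the one concentration tested (going by the name of the read-out) and lower numbers for less inhibition. Compound 2 `O=C(CCCSC[C@H](NC(=O)OCc1ccccc1)C(=O)Nc1ccccc1)NCc1ccccc1` bears benzyl and gives 30%. Among the measured compounds shown here, the one counted step so far, a number 15 percentage points higher from compound 1 to compound 2 (beyond the scatter), is the only movement beyond the scatter in this set. Compound 3 `CCCCCCCCNC(=O)CCCSC[C@H](NC(=O)OCc1ccccc1)C(=O)Nc1ccccc1` bears octyl and stands without a number, being reported in this assay as "not active" (no number reported); so no magnitude can be placed beside it, only that the long chain did not register.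

Compound 4 `CCCCNC(=O)CCCSC[C@H](NC(=O)OCc1ccccc1)C(=O)Nc1ccccc1` differs from compound 3 in one place: hydrogen in place of butyl on a saturated chain carbon, four bonds along the chain from an amide-type nitrogen. For the measured compounds named here, no measured step matches this shortening of the chain; the step from compound 1 to compound 2 concerns a phenyl for methyl exchange and does not bear on it directly. The expectation therefore rests on compound 1 at 15% and compound 3 without a number: butyl sits between ethyl and octyl, so a weak read-out is expected, possibly again reported without a number. Compound 4 is estimated at 12%, in the range 0% to 28%.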

Compound 4, a percentage reported as inhibition, at one concentration (the size of the read-out at that concentration, not a potency): 26%
Compound 4: the middle estimate sits 14 percentage points below what was measured; low and high end bracket the measured number.
By their numbers in this assay, from the lowest: compound 1; then compounds 4 and 2 (each within the scatter of the next).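

With butyl on the amide nitrogen, a plain saturated chain gives a clear read-out in this assay: a number 11 percentage points higher from compound 1 to compound 4 (beyond the scatter), so extending ethyl to butyl moves the number beyond the scatter, while compound 3, with octyl, stands as "not active" (no number reported) here. Benzyl is thus not the only group on this nitrogen to reach this level, as the comparison with the butyl chain shows: a number 4 percentage points lower from compound 2 to compound 4 (within the scatter). The data at hand give no explanation for either step.

Where the read-out fades along the way from butyl to octyl remains open, a question that hexyl could address. Also open, on these data alone, is what an amine or a carboxylic acid on the chain would do to the inhibition.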